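The source may report more compounds than this note shows. Statements on the series, on what has been measured and on what is new or still open speak of the compounds shown alone.

Compound 1 `Oc1cccc(-c2cc(-c3cccnc3)nc(-c3cccc(Cl)c3)c2)c1`: "not determined" (no result reported) in a functional assay on DU-145 cells (Homo sapiens) for cytotoxicity, read by CCK-8 assay and cell counting, with a stated time of 2 days; on this read-out lower numbers stand for stronger inhibition and higher numbers for weaker inhibition. Compound 2 `Oc1ccc(-c2cc(-c3ccccc3)nc(-c3ccccc3Cl)c2)cc1`: 2800 nM in this assay. Compound 3 `Oc1cccc(-c2cc(-c3cccnc3)nc(-c3ccccc3Cl)c2)c1`: "not determined" (no result reported) in this assay.

Compound 1 thus stands without a number of its own, as does compound 3, so compound 2 is the only one that gives a measured value. Compound 4 `Oc1cccc(-c2cc(-c3cccc(Cl)c3)nc(-c3ccco3)c2)c1` arises from compound 1 through one change: furan-2-yl in place of pyridin-3-yl on an aromatic carbon. With no value for compound 1, the size of this step in this assay cannot be read from the data, and no direction is claimed for it. The expectation for compound 4 therefore rests on compound 2 alone, whose value of 2800 nM sets the rough scale. Compound 4 is estimated at 3000 nM, within a range of 800 nM to 12000 nM.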

Compound 4, half-maximal inhibitory concentration: 2020 nM
Compound 4: middle estimate off by 1.5-fold (0.17 log units), on the high side, and the stated range covers the measured number.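

Among these compounds, compound 1 carries no number, so no step from it to compound 4 can be read. The compounds shown leave open how furan-2-yl compares with pyridin-3-yl at this place in this assay. No supporting evidence bears on this result.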